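Piperazine oxadiazole amide in place of a diethylamide

The source may report more compounds than this note shows. Statements on the series, on what has been measured and on what is new or still open speak of the compounds shown alone.

Compound 1 `CCN(CC)C(=O)[C@@H]1CCCN(S(=O)(=O)c2ccc(S(=O)(=O)N(CC)CC)cc2)C1` was tested in a functional assay on MIA PaCa-2 cells (Homo sapiens) for inhibition, read by MTT assay, with a stated time of 3 days (on this read-out lower numbers stand for stronger inhibition and higher numbers for weaker inhibition), and gave 700 nM. Among the two compounds with numbers, compound 1 stands highest; compound 2 `CCOC(=O)[C@@H]1CCCN(S(=O)(=O)c2ccc(S(=O)(=O)N(CC)CC)c(F)c2)C1` gives 200 nM in this assay, a lower number that lies beyond the usual scatter. Among the measured compounds shown here, compound 2 differs from compound 1 in more than one place, so no single step between the two is recorded.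

Compound 3 `CCN(CC)S(=O)(=O)c1ccc(S(=O)(=O)N2CCC[C@@H](C(=O)N3CCN(c4nc(C)no4)CC3)C2)cc1` has not yet been measured in this assay. It arises from compound 1 by a single change: 4-(3-methyl-1,2,4-oxadiazol-5-yl)piperazin-1-yl in place of diethylamino on a carbonyl carbon. For the measured compounds named here, no step between two measured compounds matches this change, so the expectation rests on compound 1 alone. For compound 3 the number in this assay is expected to be 400 nM, within a range from 100 nM to 1600 nM. The estimated step of a 1.8-fold lower number from compound 1 to compound 3 (0.24 log units; within the scatter) is expected to be a modest move toward a lower number, close to the edge of the scatter.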

Compound 3, half-maximal inhibitory concentration: 200 nM
Estimate against measurement, compound 3: 2.0-fold (0.30 log units) above; low and high end bracket the measured number.
By their numbers in this assay, from the lowest: compounds 2 and 3 (each within the scatter of the next); then compound 1.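

In this assay putting 4-(3-methyl-1,2,4-oxadiazol-5-yl)piperazin-1-yl in place of diethylamino on the carbonyl carbon gives a 3.5-fold lower number from compound 1 to compound 3 (0.54 log units; beyond the scatter) and so shows that this position accepts a group with a five-membered aromatic ring and a six-membered non-aromatic ring without any loss of inhibition. The earlier compounds shown here could not show this, as compound 2 differs from compound 1 in more than one place and gave no single step at this position. No measured evidence bears on why the number falls with this change.

On these data alone, whether the 3-methyl-1,2,4-oxadiazol-5-yl ring is needed, or whether an unsubstituted piperazin-1-yl or a morpholine on the same carbonyl carbon would serve as well, stays open. Also open, as far as these compounds go, is whether the same replacement would give a similar step on the fluorine-bearing core of compound 2.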